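Para substituent swap on the shared core

The compounds below may be only part of what the source reports. "The series", "measured", "known", "first", "only" and "open" are said of these compounds alone.

Compound 3 `CC(C)(C)c1ccc(N2C(=O)C=CC2OCC(F)(F)F)cc1` has the highest number of the three measured in a functional assay on HeLa cells (Homo sapiens) for inhibition (on this read-out lower numbers stand for stronger inhibition and higher numbers for weaker inhibition), where compound 3 gives 18100 nM. Compound 1 `CCc1ccc(N2C(=O)C=CC2OCC(F)(F)F)cc1` gives 6510 nM and compound 2 `O=C1C=CC(OCC(F)(F)F)N1c1ccc([N+](=O)[O-])cc1` gives 2380 nM. The steps into compound 3 both rise: a 2.8-fold higher number from compound 1 to compound 3 (0.44 log units; beyond the scatter) and a 7.6-fold higher number from compound 2 to compound 3 (0.88 log units; beyond the scatter), with ethyl and nitro each replaced by tert-butyl on the aromatic carbon.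

Compound 4 `O=C1C=CC(OCC(F)(F)F)N1c1ccc(Br)cc1` differs from compound 3 by bromo in place of tert-butyl on an aromatic carbon. Going by the values given here, no measured step carries bromo, so the size of the change rests on the two steps into compound 3, which show that tert-butyl in this position gives the highest number of the set, while ethyl and nitro do not. The step from compound 3 to compound 4 is therefore expected to go downward in this assay by roughly a 4.0-fold lower number from compound 3 to compound 4 (0.60 log units; beyond the scatter), landing between the values of compound 1 and compound 2 rather than beyond them. Compound 4 is estimated at 4500 nM, with a range from 1500 nM to 13000 nM.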

Compound 4, half-maximal inhibitory concentration: 7060 nM
Estimate against measurement, compound 4: 1.6-fold (0.20 log units) below; low and high end bracket the measured number.
By their numbers in this assay, from the lowest: compound 2; then compounds 1 and 4 (each within the scatter of the next); then compound 3.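

In this assay bromo falls with ethyl rather than at either end of the set (a 1.1-fold higher number from compound 1 to compound 4 (0.04 log units; within the scatter)), so these two groups cannot be told apart at this position on the present numbers. Bromo does separate from the two remaining groups (a 2.6-fold lower number from compound 3 to compound 4 (0.41 log units; beyond the scatter); a 3.0-fold higher number from compound 2 to compound 4 (0.47 log units; beyond the scatter)), which leaves tert-butyl and nitro as the two groups that stand apart from this pair. No measured data on hand offer an explanation for this order.

Still open, on these data alone, is how an amine, a carboxylic acid or a longer chain would read on this aromatic carbon. Also open, as far as these compounds go, is whether the same order of the four groups would hold after a change elsewhere on the shared core.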